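Extending an Ester Tail on a Shared Core

The source may report more compounds than this note shows. Statements on the series, on what has been measured and on what is new or still open speak of the compounds shown alone.

Compound 1 `Cc1c(F)c(N)c2c(=O)cc(-c3ccc(N)c(F)c3)oc2c1F` is the starting point. In a functional assay on MCF7 cells (Homo sapiens) for cytotoxicity, read by neutral red uptake, with a stated time of 3 days (on this read-out lower numbers stand for stronger inhibition and higher numbers for weaker inhibition), compound 1 gives 13 nM. Compound 2 `CCCCc1c(F)c(N)c2c(=O)cc(-c3ccc(N)c(F)c3)oc2c1F` differs from it by propyl in place of hydrogen on a saturated chain carbon bound to an aromatic carbon; in this assay compound 2 gives 8800 nM, a step of a 680-fold higher number from compound 1 to compound 2 (2.83 log units; beyond the scatter). Compound 3 `CCC(=O)OCc1c(F)c(N)c2c(=O)cc(-c3ccc(N)c(F)c3)oc2c1F` gives 130 nM in this assay, which is a 10-fold higher number from compound 1 to compound 3 (1.00 log units; beyond the scatter) and a 68-fold lower number from compound 2 to compound 3 (1.83 log units; beyond the scatter).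

Compound 4 `CCCCCC(=O)OCc1c(F)c(N)c2c(=O)cc(-c3ccc(N)c(F)c3)oc2c1F` is not yet measured. It differs from compound 3 by propyl in place of hydrogen on a saturated chain carbon, two bonds along the chain from a carbonyl carbon. This is the same kind of change as that from compound 1 to compound 2, but not the same: there the propyl enters on a saturated chain carbon bound to an aromatic carbon, whereas here it enters on a saturated chain carbon two bonds along the chain from a carbonyl carbon. The two cores themselves differ by propanoyloxy in place of hydrogen on a saturated chain carbon bound to an aromatic carbon.

The step from compound 3 to compound 4 is expected to be a 3.8-fold higher number from compound 3 to compound 4 (0.59 log units; beyond the scatter), smaller than the earlier step, because the step of a 680-fold higher number from compound 1 to compound 2 (2.83 log units; beyond the scatter) placed the propyl directly on the carbon bound to the aromatic core while here it lengthens the ester chain. Compound 4 is therefore expected to give about 500 nM in this assay, roughly between 120 nM and 2500 nM.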

Compound 4, half-maximal inhibitory concentration: 160 nM
Estimate against measurement, compound 4: 3.1-fold (0.49 log units) above, within the range that was stated.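

In this assay, adding propyl on the ester chain gives a 1.2-fold higher number from compound 3 to compound 4 (0.09 log units; within the scatter), while compound 4 remains well apart from the other two compounds, with a 55-fold lower number from compound 2 to compound 4 (1.74 log units; beyond the scatter) and a 12-fold higher number from compound 1 to compound 4 (1.09 log units; beyond the scatter). Swapping hydrogen for propyl therefore does not have an effect of the same size on both cores in this series: the same change on two cores in this assay, a 680-fold higher number (2.83 log units; beyond the scatter) from compound 1 to compound 2 and a 1.2-fold higher number (0.09 log units; within the scatter) from compound 3 to compound 4, 550-fold (2.74 log units) apart, beyond the scatter of two such steps What this does not show is the reason for the gap, since the propyl enters at a different place in each step, so the influence of the place cannot be separated from that of the core, and two steps say nothing about other cores.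

The compounds shown leave open whether a longer chain on the ester would also stay within the scatter of compound 3. They also leave open how an amine or a carboxylic acid on that chain would read in this assay.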